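The source may hold more compounds than are shown below. What is called first, only, known or untested is meant among the compounds shown, and "the series" means these compounds.

Compound 1 `C=C1CC[C@@H]2[C@](C)(CO[Si](c3ccccc3)(c3ccccc3)C(C)(C)C)[C@H](OC(C)=O)CC[C@@]2(C)[C@@H]1C/C=C1/C(=O)OC[C@H]1O`, compound 2 `C=C1CC[C@@H]2[C@](C)(CO[Si](C)(C)C(C)(C)C)[C@H](O)CC[C@@]2(C)[C@@H]1C/C=C1/C(=O)OC[C@H]1OC(C)=O` and compound 3 `C=C1CC[C@@H]2[C@](C)(CO[Si](C)(C)C(C)(C)C)[C@H](O)CC[C@@]2(C)[C@@H]1C/C=C1/C(=O)OC[C@H]1O` were tested in a functional assay on MCF7 cells (Homo sapiens) for cytotoxicity, read by sulforhodamine B assay; a lower number here means that less compound is needed, a higher number that more compound is needed for the effect. Compound 1 gives 7.53 uM, compound 2 gives 10.4 uM, and compound 3 gives 47 uM. Compound 1 and compound 2 lie within the scatter of each other, while compound 3 stands beyond the scatter from both.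

Compound 2 and compound 3 differ in one place, (hydrogen in place of acetyl on an oxygen on a saturated carbon), and this step gave a 4.5-fold higher number from compound 2 to compound 3 (0.66 log units; beyond the scatter). Compound 4 `C=C1CC[C@@H]2[C@](C)(CO[Si](c3ccccc3)(c3ccccc3)C(C)(C)C)[C@H](O)CC[C@@]2(C)[C@@H]1C/C=C1/C(=O)OC[C@H]1O` has not yet been measured in this assay. It is made from compound 1 by the same change, (hydrogen in place of acetyl on an oxygen on a saturated carbon), at a place described in the same words as for the pair compound 2 and compound 3. The difference between the core of compound 1 and the core of compound 2 is not broken down here.

Among the measured compounds shown here, since the change is the same kind and sits in the same kind of surroundings, the step from compound 1 to compound 4 is expected to resemble the one seen from compound 2 to compound 3, that is a 4.0-fold higher number from compound 1 to compound 4 (0.60 log units; beyond the scatter), resting on the measured step of a 4.5-fold higher number from compound 2 to compound 3 (0.66 log units; beyond the scatter). One earlier example is a thin basis, so a wide range is allowed. In this assay compound 4 is therefore expected to give about 30 uM, estimated to fall between 12 uM and 75 uM.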

Compound 4, concentration for half-maximal effect: 8.15 uM
Compound 4: the middle estimate sits 3.7-fold (0.57 log units) above what was measured; the whole stated range lies above it.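

On the core of compound 1, going from acetoxy to hydroxy makes no real difference in this assay: the result is a 1.1-fold higher number from compound 1 to compound 4 (0.03 log units; within the scatter), so compound 1 and compound 4 cannot be told apart here. Set beside the earlier pair, the same change does not carry over from one core to the other at the same size: the same change on two cores in this assay, a 4.5-fold higher number (0.66 log units; beyond the scatter) from compound 2 to compound 3 and a 1.1-fold higher number (0.03 log units; within the scatter) from compound 1 to compound 4, 4.2-fold (0.62 log units) apart, beyond the scatter of two such steps This shows that in this series a step measured on one core cannot simply be transferred to another, but it does not show which feature of the cores decides the outcome, and with only two pairs it gives no general rule for when removing the acetyl matters.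

The compounds shown leave open how other groups in place of the acetyl, such as a longer acyl chain like butanoyl, a benzoyl or a methyl ether, would read in this assay on either core. They also leave open whether the same change on a third core would stay within the scatter, as it does from compound 1 to compound 4, or go beyond it, as it does from compound 2 to compound 3.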